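The compounds below may be only part of what the source reports. "The series", "measured", "known", "first", "only" and "open" are said of these compounds alone.

Measured compounds: compound 1 `Cc1ncc(-c2ccccc2NCC2=NCCN2)o1`; compound 2 `c1ccc(-c2ccccc2NCC2=NCCN2)nc1`.

Going by the values given here, in a functional assay for activation of Alpha-1D adrenergic receptor (Homo sapiens) (a lower number here means that less compound is needed, a higher number that more compound is needed for the effect), compound 2 gives 41.7 nM, the only number in the set. For compound 1 this assay reports a limit only, < 5020 nM. The step that the limit leaves unreadable from compound 1 to compound 2 is accordingly of unreadable size, as the limit of < 5020 nM in this assay, at which 1 of the 2 values shown sits, shows. Compound 3 `CC/C(=N/OC)c1ccccc1NCC1=NCCN1` is not yet measured. It differs from compound 2 by a group of 6 heavy atoms (4 carbon, 1 nitrogen, 1 oxygen; no ring) in place of a group of 6 heavy atoms (5 carbon, 1 nitrogen; one six-membered aromatic ring with 1 hetero atom), on an aromatic carbon, so an open-chain group takes the place of the pyridin-2-yl. Among the compounds with values here, no measured step bears on this change: the single step from compound 1 to compound 2 exchanges one aromatic ring for another, and its size is hidden by the limit. The expectation for compound 3 in this assay is therefore wide, with a move in either direction possible. Compound 3 is estimated at 200 nM (range 30 nM to 2000 nM). This expected step, a 4.8-fold higher number from compound 2 to compound 3 (0.68 log units; beyond the scatter), is set somewhat toward weaker activity only in the absence of any anchoring step.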

Compound 3, half-maximal effective concentration: < 5020 nM
Compound 3 ended at the assay's limit (the forecaster's own chance of this, stated with the estimate: 20%); the middle value does not contradict the limit.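

Compound 3, like compound 1, ends at a limit, so neither the step from compound 2 to compound 3 nor the step from compound 1 to compound 3 can be read: the limit of < 5020 nM in this assay, at which 2 of the 3 values shown sit.

The compounds shown leave open whether either group replacing the pyridin-2-yl of compound 2 gives a higher or a lower number.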